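Removing the acetyl from the diyne enol acetate

A few compounds are considered here, and "the series" means these few. Any claim that something is new, unique, unknown or untested is made for them only; others in the source may bear on it.

Measured so far:
compound 1 `C=CCCCCC/C=C\[C@H](O)C#CC#C[C@H](C=C)OC(C)=O` — 2.1 ug/mL
compound 2 `C=CCCCCC/C=C\[C@H](O)C#CC#C/C=C/COC(C)=O` — 7.7 ug/mL

In a functional assay on L1210 cells (Mus musculus) for cytotoxicity, read by WST assay, with a stated time of 48 h (on this read-out lower numbers stand for an effect already at smaller amounts and higher numbers for an effect only at larger amounts of compound), compound 2 gives 7.7 ug/mL, the higher of the two numbers recorded. Compound 1 gives 2.1 ug/mL in this assay. Going by the values given here, the one measured step, a 3.7-fold higher number from compound 1 to compound 2 (0.56 log units; beyond the scatter), is a swap of one seven-atom group for another on a triple-bonded carbon; the acetyl is present in both compounds of that pair.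

Compound 3 `C=CCCCCC/C=C\[C@H](O)C#CC#C/C=C/CO` is the next compound to be followed. It differs from compound 2 in one place: hydrogen in place of acetyl on an oxygen on a saturated carbon. Among the compounds with values here, no measured step touches this position, since the only step recorded keeps the acetoxy group in both members of the pair. What is expected for compound 3 therefore rests on compound 2 alone, and the expectation is a step no larger than the scatter, most plausibly toward a slightly higher number.

For compound 3 the estimated value in this assay is 10 ug/mL, with a range from 4 ug/mL to 25 ug/mL. This estimate means an expected step of a 1.3-fold higher number from compound 2 to compound 3 (0.11 log units; within the scatter).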

Compound 3, concentration for half-maximal effect: 3.1 ug/mL
Beside the measured number, compound 3's estimate is 3.2-fold (0.51 log units) above it; the whole stated range lies above it.
By their numbers in this assay, from the lowest: compounds 1 and 3 (each within the scatter of the next); then compound 2.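

In this assay, going by these compounds alone, the change from acetoxy to hydroxy on this saturated carbon gives a 2.5-fold lower number from compound 2 to compound 3 (0.40 log units; beyond the scatter), the first reading at this position, and it shows that the acetyl is not required for the effect on these cells: the compound that loses it gives the lower number. The comparison with the other acetylated compound gives a 1.5-fold higher number from compound 1 to compound 3 (0.17 log units; within the scatter), so compound 3 with its 3-hydroxyprop-1-en-1-yl group and compound 1 cannot be told apart in this assay, although the step from compound 1 to compound 2 lay beyond the scatter. No measured evidence accompanies these numbers that would explain the step on removing the acetyl.

The compounds shown leave open whether the same change on the acetoxy group of compound 1 would also give a lower number, since a single pair carries this step. They also leave open what a methyl ether, an amine or a carboxylic acid at this end of the chain would give in place of the hydroxy, so it cannot yet be said whether the free hydroxy itself matters or only the absence of the acetyl.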